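Ethynyl for thiophen-2-yl on two related cores

The source may report more compounds than this note shows. Statements on the series, on what has been measured and on what is new or still open speak of the compounds shown alone.

Compound 1 `Cc1nc(N)c2c(-c3cccs3)cn([C@@H]3O[C@H](CO)[C@@H](O)[C@H]3O)c2n1` carries a thiophen-2-yl group on its core. In a functional assay on A549 cells (Homo sapiens), read by MTT assay, with a stated time of 72 h (a higher number here means a weaker inhibitor, a lower number a stronger inhibitor), compound 1 gives > 20000 nM, which is a limit of the assay and not a number. Compound 2 `COc1nc(N)nc2c1c(-c1cccs1)cn2[C@@H]1O[C@H](CO)[C@@H](O)[C@H]1O` rests on a different core; the difference between the two cores is not broken down here. In this assay compound 2 gives > 20000 nM, again a limit rather than a measured value. Compound 3 `C#Cc1cn([C@@H]2O[C@H](CO)[C@@H](O)[C@H]2O)c2nc(C)nc(N)c12` is compound 1 with ethynyl in place of thiophen-2-yl on an aromatic carbon. In this assay compound 3 gives > 20000 nM, also a limit. The step that the two limits leave unreadable from compound 1 to compound 3 therefore cannot be sized, because both of its ends sit at the limit of > 20000 nM in this assay, at which 3 of the 3 values shown sit.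

Compound 4 `C#Cc1cn([C@@H]2O[C@H](CO)[C@@H](O)[C@H]2O)c2nc(N)nc(OC)c12` has not been measured; relative to compound 2 the change is ethynyl in place of thiophen-2-yl on an aromatic carbon. The place of this change matches that of the change from compound 1 to compound 3 word for word, so it is the same change carried onto the other core. For compound 4 the expected step in this assay is a step that the limit leaves unreadable from compound 2 to compound 4. This expectation rests on compound 2, whose value in this assay is > 20000 nM, a limit. It also rests on the step that the two limits leave unreadable from compound 1 to compound 3, which the two limits leave unreadable. The estimate for compound 4 in this assay is 30000 nM, within an expected range from 15000 nM to 100000 nM, and most probably only a limit will be reported again.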

Compound 4, half-maximal inhibitory concentration: > 100000 nM
Compound 4 gave a limit, no number; the forecaster's own chance of this, stated with the estimate: 85%; middle value at least 3.3-fold (0.52 log units) from the limit.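

In this assay compound 4 gives > 100000 nM, which is a limit of the assay and not a number. Compound 2 also stands only at a limit, so no step can be read from compound 2 to compound 4. The compounds shown leave open how much ethynyl in place of thiophen-2-yl shifts the value on either core, since all four compounds sit at limits in this assay.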